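Carboxyphenyl ether series, terminal ring change toward methylated acid

The source may report more compounds than this note shows. Statements on the series, on what has been measured and on what is new or still open speak of the compounds shown alone.

For the measured compounds named here, compound 2 `Cc1c(OCCCCOc2cccc(C(=O)O)c2)ccc(C(=O)CC2CCCC2)c1O` holds the only number in this set: in an assay on HEK293 cells for positive allosteric modulation of metabotropic glutamate receptor 2 (Rattus norvegicus), read by thallium flux, with a stated time of 2.5 min (a lower number here means that less compound is needed, a higher number that more compound is needed for the effect), compound 2 gives 451 nM. Compound 1 `COC(=O)c1ccc(OCCCCOc2ccc(C(=O)CC3CCCC3)c(O)c2C)cc1` was also run in this assay, where compound 1 gives "not determined" (no result reported), so no number is reported for it. Compound 3 `Cc1cc(OCCCCOc2ccc(C(=O)CC3CCCC3)c(O)c2C)ccc1C(=O)O` differs from compound 2 by 4-carboxy-3-methylphenyl in place of 3-carboxyphenyl on an oxygen on a saturated carbon; the carboxyphenyl ether is kept and one methyl is added to that ring. Going by the values given here, no measured step between related pairs exists for comparison, so the step from compound 2 to compound 3 is expected to be small, a 1.0-fold lower number from compound 2 to compound 3 (0.00 log units; within the scatter), and not beyond the usual scatter in either direction. Compound 3 is therefore estimated at 450 nM, within a range of 150 nM to 1400 nM.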

Compound 3, half-maximal effective concentration: 564 nM
Beside the measured number, compound 3's estimate is 1.3-fold (0.10 log units) below it; measured number inside the range.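

In this assay, for the compounds shown here, 4-carboxy-3-methylphenyl in place of 3-carboxyphenyl on an oxygen on a saturated carbon gives a 1.3-fold higher number from compound 2 to compound 3 (0.10 log units; within the scatter) as the first measured step. This position therefore accepts this change in the ring without a shift that can be told from repeat measurements. No other measurement here bears on this result.

Open, as far as these compounds go, is whether the carboxylic acid is required on this ring, for instance against a tetrazole or a primary amide. Also open, from the compounds shown here alone, is how a longer chain in place of the saturated chain would read.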